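This account rests on a few compounds, and the source may have more. Where it says the series, first, only, none or still open, it means among the compounds named here.

Of the compounds shown here, three have been measured in a functional assay on A549 cells (Homo sapiens) for antiproliferative activity, read by sulforhodamine B assay, with a stated time of 48 h (on this read-out lower numbers stand for stronger inhibition of growth and higher numbers for weaker inhibition of growth), and a fourth awaits measurement.

- Compound 1 `COc1ccc([N+](=O)[O-])c(-c2nnc(C3=C(Cl)c4ccccc4CCC3)o2)c1OC` gives 5360 nM
- Compound 2 `Cc1cc2c(cc1C)C(Cl)=C(c1nnc(-c3ccccc3)o1)CCC2` gives 1960 nM
- Compound 3 `Cc1cc2c(cc1C)C(Cl)=C(c1nnc(-c3ccc(F)cc3)o1)CCC2` gives 2810 nM

In this assay compound 3, at 2810 nM, lies within the usual scatter of both compound 2 and compound 1. The next compound to be measured is compound 4 `Cc1cc2c(cc1C)C(Cl)=C(c1nnc(-c3cccc(I)c3)o1)CCC2`, in which 3-iodophenyl stands in place of the 4-fluorophenyl of compound 3 on an aromatic carbon of a five-membered aromatic ring with 2 nitrogen and 1 oxygen. The counted difference is as follows: 3-iodophenyl in place of 4-fluorophenyl on an aromatic carbon. For the measured compounds named here, only one measured step bears on this change, the fluoro in place of hydrogen on an aromatic carbon, which gave a 1.4-fold higher number from compound 2 to compound 3 (0.16 log units; within the scatter). Going by the values given here, that step stays within the scatter, but no measured compound carries 3-iodophenyl, so it offers only limited guidance. No shift beyond the scatter is therefore expected in either direction, and the estimated change is a 1.1-fold lower number from compound 3 to compound 4 (0.05 log units; within the scatter). For compound 4 the expected value is 2500 nM, with an estimated range from 1100 nM to 5700 nM.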

Compound 4, concentration for 50% growth inhibition: 2780 nM
For compound 4 the middle estimate is 1.1-fold (0.05 log units) below the measured one; the measured number falls inside the stated range.
By their numbers in this assay, from the lowest: compounds 2, 4, 3 and 1 (each within the scatter of the next, the first and the last beyond it).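

In this assay the exchange of 4-fluorophenyl for 3-iodophenyl gives a 1.0-fold lower number from compound 3 to compound 4 (0.00 log units; within the scatter) and iodo in place of hydrogen gives a 1.4-fold higher number from compound 2 to compound 4 (0.15 log units; within the scatter) and both steps lie within the scatter. On this aromatic carbon of the five-membered ring, the phenyl of compound 2, the 4-fluorophenyl of compound 3 and the 3-iodophenyl of compound 4 therefore all stand within the scatter of one another, so a halogen of either kind on this phenyl shows no measurable separation here. No measurement at hand offers an explanation for this result.

Compounds 3 and 4 differ in both the halogen and its place on the phenyl, so these steps cannot separate the two. On these data alone, it remains open whether an amine or a carboxylic acid on this phenyl, or a longer chain in its stead, would move the number beyond the scatter.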